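Working notes: from compound 2 to compound 3

The source may hold more compounds than are shown below. What is called first, only, known or untested is meant among the compounds shown, and "the series" means these compounds.

Measured so far:
compound 1 `O=C(O)c1ccc(Cl)cc1Nc1nc2ccccc2nc1NS(=O)(=O)c1ccc(Cl)cc1` — 17000 nM
compound 2 `Cc1ccc(C2=C/C(=C\c3ccc(-c4cccc(C(=O)O)c4)o3)C(=O)O2)cc1` — > 100000 nM

In an assay for inhibition of dual specificity protein phosphatase 26 (Homo sapiens), read by fluorescence, with a stated time of 30 min (on this read-out higher numbers stand for weaker inhibition and lower numbers for stronger inhibition), compound 1 gives 17000 nM. Compound 2 gives > 100000 nM, which is a limit of the assay and not a number. Compound 2 therefore stands at the limit of > 100000 nM in this assay, at which 1 of the 2 values shown sits.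

Compound 3 `O=C1OC(c2ccc(Cl)cc2)=C/C1=C\c1ccc(-c2cccc(C(=O)O)c2)o1` differs from compound 2 by chloro in place of methyl on an aromatic carbon. Going by the values given here, no measured pair shows this change, so no step beyond the usual scatter is expected in this assay. Compound 3 is thus estimated at 100000 nM, with a range from 30000 nM to 300000 nM. The expected step is a number no higher from compound 2 to compound 3 (the limit leaves the size open).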

Compound 3, half-maximal inhibitory concentration: > 100000 nM
Compound 3: a limit, no number; the forecaster's own chance of this, stated with the estimate: 70%; the middle value lies on the limit itself.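

No step can be read from compound 2 to compound 3, since both values are limits and not numbers: the limit of > 100000 nM in this assay, at which 2 of the 3 values shown sit. The compounds shown leave open whether chloro in place of methyl changes inhibition at all.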